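Saturated Lactone Diastereomers: Configuration Change at the Cyclopropane

The source may hold more compounds than are shown below. What is called first, only, known or untested is meant among the compounds shown, and "the series" means these compounds.

Measured so far:
compound 1 `O=C1CCC[C@H]([C@@H]2C[C@H]2c2ccccc2)O1` gives > 100000 nM
compound 2 `O=C1C=CC[C@@H]([C@H]2C[C@@H]2c2ccccc2)O1` gives 34900 nM
compound 3 `O=C1C=CC[C@@H](/C=C/c2ccc([N+](=O)[O-])cc2)O1` gives > 100000 nM

All three were tested in a functional assay on HBL-100 cells (Homo sapiens) for antiproliferative activity, read by luminescence and CellTiter-Glo, with a stated time of 48 h; a lower number here means a stronger inhibitor, a higher number a weaker inhibitor. Compound 1 reaches only the limit of the assay at > 100000 nM, so no number is known for it. Compound 3 likewise sits at a limit, > 100000 nM. Within the data shown here, compound 2 stands apart with a measured value of 34900 nM; no single-point step connects it to compound 1, so the two values can only be set side by side. The same limit is shared by two of the three compounds (the limit of > 100000 nM in this assay, at which 2 of the 3 values shown sit).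

The step now taken leads from compound 1 to compound 4 `O=C1CCC[C@H]([C@H]2C[C@@H]2c2ccccc2)O1`. The change is the two compounds have the same atoms and bonds and differ only in configuration as drawn: 2 of 3 stereo elements differ; a stereocentre at a saturated ring carbon is drawn R in compound 1 and S in compound 4; a stereocentre at a saturated ring carbon is drawn R in compound 1 and S in compound 4. With compound 1 itself at a limit, there is no measured step of this kind in this assay against which to scale an expectation, and nothing here ties a configuration change to a shift in potency. Compound 4 is therefore expected to remain near the limit, with an estimated value of 100000 nM in this assay, between 30000 nM and 300000 nM, which means an expected step of a number no higher from compound 1 to compound 4 (the limit leaves the size open).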

Compound 4, half-maximal inhibitory concentration: > 100000 nM
Compound 4 ended at the assay's limit (the forecaster's own chance of this, stated with the estimate: 70%); the middle value sits exactly at the limit.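

Compound 1 and compound 4 both stand at a limit in this assay, so no step between them can be read: the limit of > 100000 nM in this assay, at which 3 of the 4 values shown sit.

The compounds shown leave open whether a change of configuration on this shared core alters potency at all.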